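Compound 4: 4-Chlorophenyl in Place of 4-Methylphenyl

The source may hold more compounds than are shown below. What is called first, only, known or untested is meant among the compounds shown, and "the series" means these compounds.

Measured compounds:
- compound 1 `Cc1nc(-c2ccc(Cl)s2)sc1COc1ccc2c(c1)OCC2CC(=O)O`: "not determined" (no result reported) in a functional assay on CHO cells for agonist activity at Free fatty acid receptor 1 (Homo sapiens), read by FLIPR and calcium flux; a higher number here means that more compound is needed for the effect, a lower number that less compound is needed
- compound 2 `Cc1ccccc1-c1nc(C)c(COc2ccc3c(c2)OCC3CC(=O)O)s1`: "not determined" (no result reported) in this assay
- compound 3 `Cc1ccc(-c2nc(C)c(COc3ccc4c(c3)OCC4CC(=O)O)s2)cc1`: 73.5 nM

Among the compounds with values here, compound 3 carries the only number in this set. In this assay, within the data shown here, compound 3 gives 73.5 nM, while compound 1 and compound 2 have no result at all, so no step between two measured compounds can be read from these data.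

Compound 4 `Cc1nc(-c2ccc(Cl)cc2)sc1COc1ccc2c(c1)OCC2CC(=O)O` differs from compound 3 in one place: chloro in place of methyl on an aromatic carbon, that is, 4-methylphenyl becomes 4-chlorophenyl. Among the measured compounds shown here, no pair of measured compounds shows what such a change does. The expectation for compound 4 therefore rests on the value of compound 3, 73.5 nM, and on the smallness of the exchange. The step from compound 3 to compound 4 is expected to be no larger than the usual scatter, a 1.1-fold lower number from compound 3 to compound 4 (0.02 log units; within the scatter), in either direction. Compound 4 is therefore estimated at 70 nM, with a likely range from 25 nM to 200 nM.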

Compound 4, half-maximal effective concentration: 85.6 nM
Compound 4: the middle estimate sits 1.2-fold (0.09 log units) below what was measured; the range from low to high includes it.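

In this assay, within the data shown here, the exchange of methyl for chloro on the six-membered aromatic ring gives a 1.2-fold higher number from compound 3 to compound 4 (0.07 log units; within the scatter), the only step in this set that can be read. At this place, para to a large group, 4-methylphenyl and 4-chlorophenyl therefore cannot be told apart, so this one-atom exchange leaves the read-out within ordinary repeat variation. Nothing at hand offers an explanation for this result.

The compounds shown leave open whether an amine or a carboxylic acid at this place would keep the number in the same range. They also do not tell whether a longer chain, such as butyl, would behave as chloro does in this assay, or whether the same exchange made elsewhere on the shared core would give a similar step.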